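Replacing the amino group of compound 2

The source may hold more compounds than are shown below. What is called first, only, known or untested is meant among the compounds shown, and "the series" means these compounds.

Compound 1 `CCc1nc(-c2ccc(OC)cc2OC(F)(F)F)c(CC)nc1NC(CC)CC`: 0.0683 h
Compound 2 `CCc1nc(-c2ccc(Cl)cc2Cl)c(CC)nc1NC(COC)COC`: 0.0417 h
Compound 3 `CCOc1nc(-c2ccc(Cl)cc2Cl)c(CC)nc1NC(CC)CC`: 1.23 h

In an in vitro ADME assay on microsomes (Rattus norvegicus) for metabolic stability (a higher number here means that the compound lasts longer, a lower number that the compound disappears faster), compound 2 and compound 1 lie within the scatter of each other at the short-lived end, and compound 3 lasts far longer, beyond the scatter. The change from compound 2 to compound 4 `CCc1nc(N(CC2CC2)CC2CC2)c(CC)nc1-c1ccc(Cl)cc1Cl` is bis(cyclopropylmethyl)amino in place of (2-methoxy-1-(methoxymethyl)ethyl)amino on an aromatic carbon on the aromatic carbon para to a 2,4-dichlorophenyl group. Going by the values given here, no measured pair differs in one place only, so the data hold no step for this exchange. Compound 3 differs from compound 2 in more than one place, and its value is not carried over. In this assay no step beyond the scatter is expected. The expected size is a 1.4-fold higher number from compound 2 to compound 4 (0.16 log units; within the scatter) and stays within the scatter. Compound 4 is expected at 0.06 h with an estimated range from 0.02 h to 0.2 h in this read-out.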

Compound 4, half-life: < 0.0167 h
Compound 4 gave a limit, no number; the forecaster's own chance of this, stated with the estimate: 10%; at least 3.5-fold (0.55 log units) between middle value and limit.
By their numbers in this assay, from the lowest: compounds 2 and 1 (each within the scatter of the next); then compound 3. At a limit, below all of these: compound 4.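

In this assay compound 4 gives < 0.0167 h, which is a limit of the assay and not a number. Bis(cyclopropylmethyl)amino in place of (2-methoxy-1-(methoxymethyl)ethyl)amino gives an at least 2.4-fold lower number from compound 2 to compound 4 (0.39 log units; beyond the scatter), the only step read at this position, and it shows that the exchange of amino group alone can shift the half-life beyond the scatter. The full size of that step stays unknown, as it ends at a limit: the limit of < 0.0167 h in this assay, at which 1 of the 4 values shown sits.

On these data alone, whether dimethylamino or a morpholine ring on this aromatic carbon would last longer than compound 2 remains open. Also open, as far as these compounds go, is whether the same exchange on compound 3 would give a step of similar size.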